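This account rests on a few compounds, and the source may have more. Where it says the series, first, only, none or still open, it means among the compounds named here.

In an in vitro functional assay on HEK285-7 cells for antagonist activity at prostaglandin D2 receptor 2 (Homo sapiens), read by BRET and beta-arrestin recruitment (a higher number here means a weaker inhibitor, a lower number a stronger inhibitor), compound 1, `Cc1nc(-c2ccc(Cl)cc2)c(CC(=O)O)s1`, gives 41000 nM. Compound 2, `O=C(O)Cc1sc(C(c2ccc(F)cc2)c2ccc(F)cc2)nc1-c1ccco1`, gives 140 nM in this assay, the lowest of the two numbers shown, and its nearest neighbour, compound 1, sits far above it, beyond the scatter. Compound 3, `O=C(O)Cc1sc(C(c2ccccc2)c2ccccc2)nc1-c1ccc(C(F)(F)F)cc1`, reaches only a limit of this assay, > 100000 nM, and reports no number; this is the limit of > 100000 nM in this assay, at which 1 of the 3 values shown sits. Compound 4, `NS(=O)(=O)c1cccc(-c2nc(C(c3ccc(F)cc3)c3ccc(F)cc3)sc2CC(=O)O)c1`, has not yet been measured in this assay. It differs from compound 2 in one place: 3-sulfamoylphenyl in place of furan-2-yl on an aromatic carbon. Among the compounds with values here, no measured pair shows this change. A modest loss is expected, within or near the scatter, as a 2.1-fold higher number from compound 2 to compound 4 (0.33 log units; beyond the scatter). For compound 4 the estimate in this assay is 300 nM, between 50 nM and 3000 nM.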

Compound 4, half-maximal inhibitory concentration: 710 nM
For compound 4 the middle estimate is 2.4-fold (0.37 log units) below the measured one, and the stated range covers the measured number.
By their numbers in this assay, from the lowest: compound 2; then compound 4; then compound 1. At a limit, above all of these: compound 3.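

In this assay, a step of a 5.1-fold higher number from compound 2 to compound 4 (0.71 log units; beyond the scatter) shows that this aromatic carbon, next to the ring nitrogen, tolerates 3-sulfamoylphenyl in place of furan-2-yl at a modest but real cost. This is the only pair shown that differs in one place, so it alone speaks to this position, and a six-membered carbon ring bearing a hydrogen-bond donor is accommodated here. Nothing measured here explains the step. Going by these compounds, what remains open is which part of 3-sulfamoylphenyl carries the loss, the phenyl ring or the sulfamoyl group. An unsubstituted phenyl or a methylsulfonyl group in its place would separate these.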